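This account rests on a few compounds, and the source may have more. Where it says the series, first, only, none or still open, it means among the compounds named here.

Compound 1 `O=C(O)CCCSCCN1C(=O)OC[C@@H]1/C=C/[C@@H](O)Cc1ccccc1` is characterised in an assay on CHO cells for displacement of a labelled ligand from prostaglandin E2 receptor EP1 subtype (Mus musculus), read by scintillation counting, with a stated time of 20 min; a lower number here means a stronger inhibitor, a higher number a weaker inhibitor. In this assay compound 1 gives > 10000 nM, which is a limit of the assay and not a number. Compound 1 thus sits at the limit of > 10000 nM in this assay, at which 2 of the 3 values shown sit. Compound 2 `CCCc1cccc(C[C@H](O)/C=C/[C@H]2CCC(=S)N2CCCCCCC(=O)O)c1` is likewise reported in this assay only as a limit, > 10000 nM. Compound 3 `Cc1cccc(C[C@H](O)/C=C/[C@H]2CCC(=S)N2CCSCCCC(=O)O)c1` gives 2800 nM in this assay, a number rather than a limit. Compound 4 `CCc1cccc(C[C@H](O)/C=C/[C@H]2COC(=O)N2CCSCCCC(=O)O)c1` has not yet been measured in this assay. It differs from compound 1 by ethyl in place of hydrogen on an aromatic carbon. Among the measured compounds shown here, no measured pair shows this single change, so the size of the step is open. For the measured compounds named here, compound 3, which carries a methyl group and a different core, is the only compound of the three with a number rather than a limit, which hints that a small alkyl group may help binding, while compound 2 with a propyl group remains a limit. Compound 4 is expected to give about 6000 nM, within 1500 nM to 20000 nM. The estimated step is an at least 1.6-fold lower number from compound 1 to compound 4 (0.22 log units; that floor lies within the scatter), a modest gain at most, and a limit result for compound 4 remains quite possible.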

Compound 4, inhibition constant: 2400 nM
Compound 4: middle estimate off by 2.5-fold (0.40 log units), on the high side; the measured number falls inside the stated range.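

In this assay, the change of phenyl to 3-ethylphenyl gives an at least 4.1-fold lower number from compound 1 to compound 4 (0.61 log units; beyond the scatter), and it is the only pair shown that differs in this one place. It gives a direct reading that the ethyl group of compound 4, meta to a large group, lowers the number by more than the usual scatter, with no other change in the shared core to confound it. The full size of the step stays unknown, because its starting point is only a limit and the step is therefore a floor: the limit of > 10000 nM in this assay, at which 2 of the 4 values shown sit.

From the compounds shown here alone, whether methyl, propyl, a longer chain or chlorine at this carbon on the core of compound 1 would do as well or better remains open. Also open, going by these compounds, is whether ethyl elsewhere on the ring would give a similar step.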